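Swapping hydroxy for amino on a low-inhibition chroman scaffold

The source may hold more compounds than are shown below. What is called first, only, known or untested is meant among the compounds shown, and "the series" means these compounds.

Measured so far:
compound 1 `COc1cccc2c1OCC(C)(C)C2N` — 4.3%
compound 2 `CC1(C)COc2ccccc2C1O` — 8%

Of the compounds shown here, two have been tested in an assay on BTI cells for inhibition of Amine oxidase [flavin-containing] B (Homo sapiens), read by fluorescence, with a stated time of 20 min, tested at 1 uM; a lower number here means less inhibition, a higher number more inhibition at the concentration tested (going by the name of the read-out). Compound 1 `COc1cccc2c1OCC(C)(C)C2N` gives 4.3%. Compound 2 `CC1(C)COc2ccccc2C1O` gives 8%. Both numbers are small, and the gap between them is within the usual scatter of repeated measurements, so the two compounds cannot be told apart on this evidence; their numbers are level.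

Compound 3 `CC1(C)COc2ccccc2C1N` has not yet been measured. It differs from compound 2 in one place: amino in place of hydroxy on a saturated ring carbon. Among the measured compounds shown here, no measured pair in this set isolates such a swap, so there is no observed step to lean on. What the two measured compounds do show is that this core gives only weak inhibition whichever of the two small groups sits at that position in compound 1 and compound 2.

For compound 3 the expectation in this assay is therefore a step of no change at the digits printed from compound 2 to compound 3 (within the scatter), that is, nothing beyond the scatter. The estimated value for compound 3 is 8%, with a range from 0% to 20%.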

Compound 3, a percentage reported as inhibition, at one concentration (the size of the read-out at that concentration, not a potency): 3.7%
Beside the measured number, compound 3's estimate is 4.3 percentage points above it; the measured number falls inside the stated range.
By their numbers in this assay, from the lowest: compounds 3, 1 and 2 (each within the scatter of the next).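

In this assay, the direct exchange of hydroxy for amino on a saturated ring carbon gives a number 4.3 percentage points lower from compound 2 to compound 3 (within the scatter) and thus shows that, on this core and at this single tested concentration, the two groups cannot be told apart, a point that compounds 1 and 2 could not settle because they differ in more than one place. The second comparison, hydrogen in place of methoxy on an aromatic carbon, gives a number 0.6 percentage points lower from compound 1 to compound 3 (within the scatter) and so adds that the methoxy group, too, makes no difference that can be read beyond the scatter when the amino group is present. Nothing available here gives a reason for these results.

From the compounds shown here alone, it remains open whether a bulkier replacement on the saturated ring carbon, such as an acetamide, a benzyloxy group or a carboxylic acid, would move the inhibition beyond the scatter. Also open, going by these compounds, is whether a halogen such as chlorine or fluorine on an aromatic carbon would change the picture, and, since each number comes from one concentration, how these compounds would behave at higher concentrations.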